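This account rests on a few compounds, and the source may have more. Where it says the series, first, only, none or still open, it means among the compounds named here.

Compound 1 `C=CCCC(COCCCCCCCCCCCCCCCCCC)NC(C)=O`, compound 2 `CCCCCCCCCCCCCCCCCCOCC(COCC(F)(F)F)NC(C)=O` and compound 3 `CCCCCCCCCCCCCCCCCCOCC(CCC(O)CO)NC(C)=O` share one core and differ only in the group carried on the chain carbon two or three bonds along the chain from the amide-type nitrogen. In an assay for inhibition of putative inactive group IIC secretory phospholipase A2 (Homo sapiens) (a higher number here means a weaker inhibitor, a lower number a stronger inhibitor), compound 1 gives 8000 nM, compound 2 gives 100000 nM and compound 3 gives 8900 nM. Compound 3 thus stands second highest of the three numbers. The nearer of its two steps is a 1.1-fold higher number from compound 1 to compound 3 (0.05 log units; within the scatter), which is within the scatter; the further one is an 11-fold lower number from compound 2 to compound 3 (1.05 log units; beyond the scatter), well beyond it.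

Compound 4 `CCCCCCCCCCCCCCCCCCOCC(CCc1nnn[nH]1)NC(C)=O` has not been measured in this assay. The change from compound 3 is 1H-tetrazol-5-yl in place of 1,2-dihydroxyethyl on a saturated chain carbon, three bonds along the chain from an amide-type nitrogen. Both measured steps sit at the same part of the chain. The step of an 11-fold lower number from compound 2 to compound 3 (1.05 log units; beyond the scatter) shows that this position can move the number by a large margin; the step of a 1.1-fold higher number from compound 1 to compound 3 (0.05 log units; within the scatter) shows that swapping one uncharged group for another there can also leave it essentially unchanged. With one donor retained and an aromatic ring entering, no large move is expected; for compound 4 the estimated step is a 1.8-fold lower number from compound 3 to compound 4 (0.25 log units; within the scatter). Compound 4 is therefore expected to give about 5000 nM, with a range from 1500 nM to 20000 nM.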

Compound 4, half-maximal inhibitory concentration: 570 nM
Compound 4: the middle estimate sits 8.8-fold (0.94 log units) above what was measured; measured number outside the range, below it.
By their numbers in this assay, from the lowest: compound 4; then compounds 1 and 3 (each within the scatter of the next); then compound 2.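

In this assay, the chain carbon three bonds along from an amide-type nitrogen now shows a large gain, with a 16-fold lower number from compound 3 to compound 4 (1.19 log units; beyond the scatter) and a 14-fold lower number from compound 1 to compound 4 (1.15 log units; beyond the scatter) beyond the scatter, whereas the earlier exchange between two groups without a ring, a 1.1-fold higher number from compound 1 to compound 3 (0.05 log units; within the scatter) within the scatter, left the number in place. Compound 4, the only one of the four with a ring on this chain, is the strongest inhibitor shown, so the hydroxyl groups of compound 3 are not required for a low number here. The range seen across this part of the chain also widens, as a 180-fold lower number from compound 2 to compound 4 (2.24 log units; beyond the scatter) far exceeds any earlier step.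

The compounds shown leave open whether the gain belongs to the 1H-tetrazol-5-yl ring itself, since a carboxylic acid, a 1,2,4-triazole or a methyl group on a tetrazole nitrogen in the same place, or a longer chain leading to the ring, would separate these readings. Nothing at hand explains why the number falls with this change.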